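This account rests on a few compounds, and the source may have more. Where it says the series, first, only, none or still open, it means among the compounds named here.

Of the compounds shown here, three that share one core have been measured. Compound 1 `CCC(=O)Nc1ccc(S(=O)(=O)Oc2ccccc2I)cc1` in a functional assay on HT-29 cells (Homo sapiens) for antiproliferative activity, read by sulforhodamine B assay, with a stated time of 48 h (on this read-out higher numbers stand for weaker inhibition and lower numbers for stronger inhibition), gives 11000 nM. Compound 2 `CC(C)C(=O)Nc1ccc(S(=O)(=O)Oc2ccccc2I)cc1` in this assay gives 13000 nM, a step of a 1.2-fold higher number from compound 1 to compound 2 (0.07 log units; within the scatter). Compound 3 `O=C(CCCCl)Nc1ccc(S(=O)(=O)Oc2ccccc2I)cc1` in this assay gives 9100 nM. Set against the other two, compound 3 stands at a 1.2-fold lower number from compound 1 to compound 3 (0.08 log units; within the scatter) and a 1.4-fold lower number from compound 2 to compound 3 (0.15 log units; within the scatter), so all three numbers sit together within the usual scatter, and none of them can be called stronger or weaker than another.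

Compound 4 `O=C(Nc1ccc(S(=O)(=O)Oc2ccccc2I)cc1)NC1CC1` is the next step: cyclopropylamino in place of 3-chloropropyl on a carbonyl carbon. Among the measured compounds shown here, every measured step so far changed the group on that same carbonyl carbon, and each stayed within the scatter: a 1.2-fold higher number from compound 1 to compound 2 (0.07 log units; within the scatter), a 1.2-fold lower number from compound 1 to compound 3 (0.08 log units; within the scatter) and a 1.4-fold lower number from compound 2 to compound 3 (0.15 log units; within the scatter). None of those steps brought in a nitrogen or a ring at that place, so they are only a loose guide, but they give no sign that this position moves the number. For compound 4 the expected step is therefore a 1.1-fold higher number from compound 3 to compound 4 (0.04 log units; within the scatter), within the scatter. The estimate for compound 4 in this assay is 10000 nM, with a range from 4000 nM to 25000 nM.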

Compound 4, half-maximal inhibitory concentration: 14000 nM
Compound 4: middle estimate off by 1.4-fold (0.15 log units), on the low side; low and high end bracket the measured number.
By their numbers in this assay, from the lowest: compounds 3, 1, 2 and 4 (each within the scatter of the next).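

Compound 4 puts a nitrogen, a ring and a hydrogen-bond donor on a carbonyl carbon whose other neighbour is an amide-type nitrogen, features that none of the earlier groups at this place carried. Even so, in this assay every new step stays within the scatter: a 1.5-fold higher number from compound 3 to compound 4 (0.19 log units; within the scatter), a 1.1-fold higher number from compound 2 to compound 4 (0.03 log units; within the scatter) and a 1.3-fold higher number from compound 1 to compound 4 (0.10 log units; within the scatter). This place has therefore now taken cyclopropylamino as well as open chains with no readable shift in the number, and no supporting evidence on the reason for this is available.

Still open, on these data alone, is what a larger group at this carbonyl carbon, such as a phenyl ring, a longer chain or a carboxylic acid, would do to the number. These four compounds also say nothing about changes elsewhere on the shared core.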